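The source may hold more compounds than are shown below. What is called first, only, known or untested is meant among the compounds shown, and "the series" means these compounds.

Compound 1 `Cc1cccc(-n2cc(COc3cccc(NC(=O)Nc4ccc(Cl)c(C(F)(F)F)c4)c3)nn2)c1` gives 7270 nM in a functional assay on HepG2 cells (Homo sapiens) for inhibition, read by MTT assay, with a stated time of 72 h; a higher number here means a weaker inhibitor, a lower number a stronger inhibitor.
Compound 2 `CCc1cccc(-n2cc(COc3cccc(NC(=O)Nc4ccc(Cl)c(C(F)(F)F)c4)c3)nn2)c1` gives 37900 nM in this assay.
Compound 3 `O=C(Nc1cccc(OCc2cn(-c3cccc(I)c3)nn2)c1)Nc1ccc(Cl)c(C(F)(F)F)c1` gives 4780 nM in this assay.

These three compounds share one core and differ only in the group that sits on the outer aromatic ring. Compound 2, which carries an ethyl there, gives the highest number of the three, so it is the weakest inhibitor in this assay: the step of a 5.2-fold higher number from compound 1 to compound 2 (0.72 log units; beyond the scatter) and the step of a 7.9-fold lower number from compound 2 to compound 3 (0.90 log units; beyond the scatter) both lie beyond the scatter. Between compound 1 and compound 3 the step of a 1.5-fold lower number from compound 1 to compound 3 (0.18 log units; within the scatter) stays within the scatter, so no order between those two can be read.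

Compound 4 `O=C(Nc1cccc(OCc2cn(-c3cccc(C(F)(F)F)c3)nn2)c1)Nc1ccc(Cl)c(C(F)(F)F)c1` is not yet measured. It differs from compound 2 in one place: trifluoromethyl in place of ethyl on an aromatic carbon. For the measured compounds named here, the steps that bear on this change are the two that lead away from the ethyl, a 5.2-fold higher number from compound 1 to compound 2 (0.72 log units; beyond the scatter) and a 7.9-fold lower number from compound 2 to compound 3 (0.90 log units; beyond the scatter), both modest and both pointing to a lower number when the ethyl is removed. Going by the values given here, no measured step tells how a trifluoromethyl itself behaves on this ring. It is therefore expected that compound 4 moves to a lower number, by about a 4.7-fold lower number from compound 2 to compound 4 (0.68 log units; beyond the scatter), landing near compound 1 and compound 3. The estimate for compound 4 is 8000 nM, with a range from 3000 nM to 30000 nM.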

Compound 4, half-maximal inhibitory concentration: 1270 nM
The estimate for compound 4 lay 6.3-fold (0.80 log units) above the measured number, and the stated range ends above it.
By their numbers in this assay, from the lowest: compound 4; then compounds 3 and 1 (each within the scatter of the next); then compound 2.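

In this assay the group on this aromatic carbon can do more than recover what the ethyl lost: the change from ethyl to trifluoromethyl gives the largest step seen so far in this series (a 30-fold lower number from compound 2 to compound 4 (1.47 log units; beyond the scatter)). The earlier compounds offered only methyl and iodo, which sit within the scatter of each other, whereas trifluoromethyl stands clearly apart from both (a 3.8-fold lower number from compound 3 to compound 4 (0.58 log units; beyond the scatter); a 5.7-fold lower number from compound 1 to compound 4 (0.76 log units; beyond the scatter)), making compound 4 the strongest inhibitor of the four shown. So this one place on the outer ring spans a wide range of numbers while the rest of the molecule stays the same, but nothing measured here says why trifluoromethyl and ethyl, two small groups without a ring, lie so far apart.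

The four compounds shown leave open whether other groups at this place, such as a nitrile, a methoxy, an amine, a carboxylic acid or a longer chain like propyl, would reach or pass trifluoromethyl. On these data alone, it also stays open whether the swap from ethyl to trifluoromethyl would give a step of this size on any other carbon of that ring.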